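From Fluoro to Bromo: an Estimate for Compound 3

A few compounds are considered here, and "the series" means these few. Any claim that something is new, unique, unknown or untested is made for them only; others in the source may bear on it.

Compound 1 `COc1ccc2[nH]c(=O)c(-c3nc4cc(F)ccc4[nH]3)cc2c1` and compound 2 `O=c1[nH]c2ccccc2cc1-c1nc2cc(F)ccc2[nH]1` share one core and differ in a single place. In a functional assay on BEL-7404 cells for cytotoxicity against BEL-7404 tumor cell line (Homo sapiens), read by MTT assay, with a stated time of 48 h (a higher number here means a weaker inhibitor, a lower number a stronger inhibitor), compound 1 gives > 100000 nM, which is a limit of the assay rather than a number (the limit of > 100000 nM in this assay, at which 1 of the 2 values shown sits). In this assay, going by the values given here, compound 2 gives 27500 nM, and it is the only compound for which a number, not a limit, was obtained. Among the compounds with values here, the step of an at least 3.6-fold lower number from compound 1 to compound 2 (0.56 log units; beyond the scatter) is the one measured comparison available.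

Compound 3 `O=c1[nH]c2ccccc2cc1-c1nc2cc(Br)ccc2[nH]1` differs from compound 2 by bromo in place of fluoro on an aromatic carbon. Within the data shown here, the measured step concerns a methoxy replaced by hydrogen and says nothing about exchanging one halogen for another, so no measured step bears directly on this change. He therefore expects in this assay a step that stays within the scatter or leans slightly toward a lower number. For compound 3 he estimates 15000 nM, with a range from 4000 nM to 60000 nM. This estimate corresponds to an expected step of a 1.8-fold lower number from compound 2 to compound 3 (0.26 log units; within the scatter).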

Compound 3, half-maximal inhibitory concentration: 14500 nM
Compound 3: middle estimate off by 1.0-fold (0.01 log units), on the high side; low and high end bracket the measured number.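

In this assay, bromo in place of fluoro on the aromatic carbon gives a 1.9-fold lower number from compound 2 to compound 3 (0.28 log units; within the scatter), so at this position the two halogens cannot be told apart. Going by these compounds alone, this is the first reading at this place, since the earlier step concerned only a methoxy replaced by hydrogen, and with either halogen here the result is a number rather than a limit of the assay. Nothing measured here gives a reason for this result.

The compounds shown leave open how this position responds to a group other than a halogen, such as an amine or a carboxylic acid. They also leave open whether chloro or plain hydrogen at this place would fall in line with fluoro and bromo.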